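The source may report more compounds than this note shows. Statements on the series, on what has been measured and on what is new or still open speak of the compounds shown alone.

In a functional assay on Huh-7 cells (Homo sapiens) for cytotoxicity, read by MTT assay, with a stated time of 72 h (on this read-out lower numbers stand for higher toxicity in this test and higher numbers for lower toxicity in this test), compound 1 `CS(=O)(=O)N1CCC2(CC1)OOC1(CCCC1)OO2` gives > 100 ug/mL as a limit, not a number. Compound 2 `O=S(=O)(Cc1ccccc1)N1CCC2(CC1)OOC1(CCCC1)OO2` gives > 100 ug/mL as a limit as well. That leaves compound 2 placed only by the limit of > 100 ug/mL in this assay, at which 2 of the 2 values shown sit, and by nothing finer. In compound 3 `COc1ccc(S(=O)(=O)N2CCC3(CC2)OOC2(CCCC2)OO3)cc1` the change is 4-methoxyphenyl in place of benzyl on a sulfonyl sulfur with 4-methoxyphenyl in place of benzyl on a sulfonyl sulfur, while the shared core stays as it is. Going by the values given here, the only measured step that bears on this is a step that the two limits leave unreadable from compound 1 to compound 2 and it offers no size to carry over, so neither a step beyond the scatter nor a direction is expected in this assay for this change. The estimated step is a number no higher from compound 2 to compound 3 (the limit leaves the size open) and it remains an expectation only. For compound 3 the estimated value is 100 ug/mL with an expected range from 40 ug/mL up to 200 ug/mL as the likely span.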

Compound 3, half-maximal cytotoxic concentration: > 100 ug/mL
Compound 3: no number, only a limit; the forecaster's own chance of this, stated with the estimate: 70%; the middle value lies on the limit itself.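

No new step can be read among compound 1, compound 2 and compound 3, as each gives only a limit and no number: the limit of > 100 ug/mL in this assay, at which 3 of the 3 values shown sit. The compounds shown leave open whether the group on the sulfonyl sulfur changes the read-out in this assay at all.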